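Oxazole to Trimethyl-dioxoimidazolidine on the Benzylic Arm

The source may hold more compounds than are shown below. What is called first, only, known or untested is meant among the compounds shown, and "the series" means these compounds.

Three measured compounds share one core and differ only in the group carried on a saturated chain carbon bound to an aromatic carbon. Compound 1 `CCCCOC(=O)NS(=O)(=O)c1sc(CC(C)C)cc1-c1ccc(Cn2cccn2)cc1` carries a 1H-pyrazol-1-yl group there, and in an assay on membranes from uterus for displacement of a labelled ligand from Angiotensin type II receptor (Sus scrofa), with a stated time of 1.5 h (on this read-out lower numbers stand for stronger inhibition and higher numbers for weaker inhibition), compound 1 gives 2.3 nM. Compound 2 `CCCCOC(=O)NS(=O)(=O)c1sc(CC(C)C)cc1-c1ccc(CN2CCN(C)C2=O)cc1` carries a 3-methyl-2-oxoimidazolidin-1-yl group, and in this assay compound 2 gives 16.5 nM. Compound 3 `CCCCOC(=O)NS(=O)(=O)c1sc(CC(C)C)cc1-c1ccc(Cc2ncco2)cc1` carries a 1,3-oxazol-2-yl group, and in this assay compound 3 gives 3.9 nM. Compound 3 thus holds the second highest number of the three: it sits within the scatter of compound 1, as a 1.7-fold higher number from compound 1 to compound 3 (0.23 log units; within the scatter) shows, while it is separated from compound 2 by a 4.2-fold lower number from compound 2 to compound 3 (0.63 log units; beyond the scatter).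

The change leading to compound 4 `CCCCOC(=O)NS(=O)(=O)c1sc(CC(C)C)cc1-c1ccc(CN2C(=O)N(C)C(C)(C)C2=O)cc1` is 3,4,4-trimethyl-2,5-dioxoimidazolidin-1-yl in place of 1,3-oxazol-2-yl on a saturated chain carbon bound to an aromatic carbon. The step that bears most on it is a 4.2-fold lower number from compound 2 to compound 3 (0.63 log units; beyond the scatter), read in reverse, since the entering group resembles the 3-methyl-2-oxoimidazolidin-1-yl group of compound 2 far more than the aromatic group it replaces; a 7.2-fold higher number from compound 1 to compound 2 (0.86 log units; beyond the scatter) points the same way. Compound 4 is therefore expected to show a modest rise, a 3.8-fold higher number from compound 3 to compound 4 (0.59 log units; beyond the scatter), in this assay. The estimate for compound 4 is 15 nM, with a range from 4 nM to 50 nM.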

Compound 4, inhibition constant: 3.6 nM
Compound 4: middle estimate off by 4.2-fold (0.62 log units), on the high side; measured number below the stated range.
By their numbers in this assay, from the lowest: compounds 1, 4 and 3 (each within the scatter of the next); then compound 2.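

In this assay the result shows that a non-aromatic ring on this saturated chain carbon need not go with the higher number seen for compound 2: a 1.1-fold lower number from compound 3 to compound 4 (0.03 log units; within the scatter) and a 1.6-fold higher number from compound 1 to compound 4 (0.19 log units; within the scatter) both leave compound 4 within the scatter of the aromatic groups, and a group of 10 heavy atoms reads here like one of 5. The two non-aromatic rings themselves now part, with a 4.6-fold lower number from compound 2 to compound 4 (0.66 log units; beyond the scatter) for 3,4,4-trimethyl-2,5-dioxoimidazolidin-1-yl in place of 3-methyl-2-oxoimidazolidin-1-yl, so the outcome at this position follows the particular ring and not simply the loss of aromaticity. Nothing in hand offers an explanation for this separation between the two rings.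

The compounds shown leave open which part of the difference between compound 2 and compound 4 carries that step, as none has the second ring carbonyl without the added methyl groups, or the methyl groups without that carbonyl. On these data alone, how a carboxylic acid or an amine on this saturated chain carbon would read also stays open.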